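A few compounds are considered here, and "the series" means these few. Any claim that something is new, unique, unknown or untested is made for them only; others in the source may bear on it.

Three compounds built on a shared core have been examined in an ADME assay on L6 cells (Rattus norvegicus) for cytotoxicity; on this read-out higher numbers stand for weaker inhibition and lower numbers for stronger inhibition. Compound 1 `C[C@H]1O[C@@H](n2cnc3c(N)nc(Cl)nc32)[C@H](O)[C@@H]1O` gives 147000 nM. Compound 2 `CS[C@H]1O[C@@H](n2cnc3c(N)nc(Cl)nc32)[C@H](O)[C@@H]1O` gives 271000 nM. Compound 3 `CS[C@H]1O[C@@H](n2cnc3c(N)nc(N=[N+]=[N-])nc32)[C@H](O)[C@@H]1O` gives 236000 nM. Compound 1 holds the lowest of the three numbers, but its gaps to compound 3 and to compound 2 both lie within the scatter, so no order among them is established. Methylsulfanyl in place of methyl on a saturated ring carbon gave a 1.8-fold higher number from compound 1 to compound 2 (0.27 log units; within the scatter), and azido in place of chloro on an aromatic carbon gave a 1.1-fold lower number from compound 2 to compound 3 (0.06 log units; within the scatter).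

Compound 4 `C[C@H]1O[C@@H](n2cnc3c(N)nc(C#N)nc32)[C@H](O)[C@@H]1O` differs from compound 1 by cyano in place of chloro on an aromatic carbon. The step that bears on this exchange is the other replacement of chloro on an aromatic carbon, which gave a 1.1-fold lower number from compound 2 to compound 3 (0.06 log units; within the scatter). Because that step stayed within the scatter, no movement beyond the scatter is expected here either. Compound 4 is therefore expected to give 150000 nM in this assay, within a range from 60000 nM to 370000 nM. The expected step is a 1.0-fold higher number from compound 1 to compound 4 (0.01 log units; within the scatter).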

Compound 4, half-maximal inhibitory concentration: 177000 nM
Beside the measured number, compound 4's estimate is 1.2-fold (0.07 log units) below it; the range from low to high includes it.
By their numbers in this assay, from the lowest: compounds 1, 4, 3 and 2 (each within the scatter of the next).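

In this assay, cyano in place of chloro on an aromatic carbon between two ring nitrogen atoms gave a 1.2-fold higher number from compound 1 to compound 4 (0.08 log units; within the scatter). With a 1.1-fold lower number from compound 2 to compound 3 (0.06 log units; within the scatter), this position has now taken two different replacements of chloro, one alongside the methyl group and one alongside the methylsulfanyl group, and both steps stay within the scatter. The triple bond and hydrogen-bond acceptor that enter with cyano therefore came with no movement beyond the scatter, and no supporting measurement bears on this result.

On these data alone, whether a carboxylic acid or a longer alkyl chain at this position would give a step beyond the scatter remains open. As far as these compounds go, it is also open whether cyano would behave the same way alongside the methylsulfanyl group.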